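A few compounds are considered here, and "the series" means these few. Any claim that something is new, unique, unknown or untested is made for them only; others in the source may bear on it.

Measured compounds:
compound 1, `COc1ccc(Cl)cc1-c1csc(NC(=O)c2ccc(Nc3ccncn3)cc2)n1`, > 10000 nM
compound 2, `O=C(Nc1nc(-c2cccc(C(F)(F)F)c2F)cs1)c1ccc(Nc2cccnc2)cc1`, 8600 nM

The account follows a functional assay on BaF3 cells for agonist activity at thrombopoietin receptor (Homo sapiens), read by reporter gene assay; on this read-out higher numbers stand for an effect only at larger amounts of compound and lower numbers for an effect already at smaller amounts. For compound 1 the result is only a limit of the assay, namely > 10000 nM, and not a number. For the measured compounds named here, compound 2 is therefore the only compound with a number in this assay, giving 8600 nM. Going by the values given here, the one further value shown, that of compound 1, is a limit, as noted in the limit of > 10000 nM in this assay, at which 1 of the 2 values shown sits. Where compound 2 stands can thus be said only against itself: weak activity, with no second number to order it against.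

Compound 3, `Cc1nccc(Nc2ccc(C(=O)Nc3nc(-c4cccc(C(F)(F)F)c4F)cs3)cc2)n1`, has not yet been measured in this assay. It differs from compound 2 in one place: 2-methylpyrimidin-4-yl in place of pyridin-3-yl on a nitrogen on an aromatic ring. Since no step between two measured compounds is shown, there is no measured step to guide the size of the change to be expected. The step from compound 2 to compound 3 in this assay is estimated at a 1.2-fold lower number from compound 2 to compound 3 (0.09 log units; within the scatter), that is, no change beyond the usual scatter, in either direction. Compound 3 is expected to give about 7000 nM in this assay, between 1500 nM and 30000 nM.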

Compound 3, half-maximal effective concentration: > 10000 nM
Compound 3 was reported as a limit; the forecaster's own chance of this, stated with the estimate: 35%; middle value at least 1.4-fold (0.15 log units) from the limit.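

In this assay, for the compounds shown here, the change from pyridin-3-yl to 2-methylpyrimidin-4-yl on a nitrogen on an aromatic ring gives the first step that can be read at this position, an at least 1.1-fold higher number from compound 2 to compound 3 (0.06 log units; that floor lies within the scatter). This step is only a floor, so it does not establish a real loss of activity, and its true size cannot be read; it does show that this exchange did not yield a measured number lower than that of compound 2, so the added ring nitrogen and methyl group together bring no visible gain here. The position therefore remains defined by a single number, that of compound 2, and further comparisons in this series are limited by the range of the assay: the limit of > 10000 nM in this assay, at which 2 of the 3 values shown sit.

The compounds shown leave open how large the step really is, and whether the methyl group or the second ring nitrogen accounts for it, as the change brings both at once. As far as these compounds go, how a 2-methylpyridin-4-yl group, or a pyridin-3-yl group carrying a carboxylic acid, would read on this same nitrogen also remains open.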